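Sulfonamide nitrogen substituents and antiproliferative potency on one core

This account rests on a few compounds, and the source may have more. Where it says the series, first, only, none or still open, it means among the compounds named here.

Compound 1 `CN(c1ccccc1)S(=O)(=O)C1CC2OC1C(c1ccc(NC(=O)CCCCCCC(=O)O)cc1)=C2c1ccc(O)cc1`: in a functional assay on DU-145 cells (Homo sapiens) for antiproliferative activity, read by MTT assay, with a stated time of 72 h (on this read-out lower numbers stand for stronger inhibition and higher numbers for weaker inhibition), compound 1 gives only the limit > 100000 nM.
Compound 2 `Cc1ccc(N(C)S(=O)(=O)C2CC3OC2C(c2ccc(NC(=O)CCCCCCC(=O)O)cc2)=C3c2ccc(O)cc2)cc1`: compound 2 gives only the limit > 100000 nM.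
Compound 3 `CCN(c1ccc(OC)cc1)S(=O)(=O)C1CC2OC1C(c1ccc(NC(=O)CCCCCCC(=O)O)cc1)=C2c1ccc(O)cc1`: compound 3 gives 24400 nM.

Compound 1 therefore stands at the limit of this assay, sharing it with compound 2, as the limit of > 100000 nM in this assay, at which 2 of the 3 values shown sit, records. Compound 4 `CCN(c1ccccc1Br)S(=O)(=O)C1CC2OC1C(c1ccc(NC(=O)CCCCCCC(=O)O)cc1)=C2c1ccc(O)cc1` differs from compound 1 in that ((2-bromophenyl)(ethyl)amino in place of methyl(phenyl)amino on a sulfonyl sulfur). For the measured compounds named here, the steps that bear on this change are an at least 4.0-fold lower number from compound 1 to compound 3 (0.61 log units; beyond the scatter) and an at least 4.0-fold lower number from compound 2 to compound 3 (0.61 log units; beyond the scatter); both bring in ethyl(4-methoxyphenyl)amino, whereas compound 4 brings in (2-bromophenyl)(ethyl)amino, sharing the ethyl but not the aryl group. Only compound 3 supplies a measured number, so the expected step is a modest lowering, estimated as an at least 2.0-fold lower number from compound 1 to compound 4 (0.30 log units; that floor lies within the scatter), with a real chance of another limit. Compound 4 is accordingly expected near 50000 nM, between 15000 nM and 150000 nM.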

Compound 4, half-maximal inhibitory concentration: 95300 nM
Compound 4: the middle estimate sits 1.9-fold (0.28 log units) below what was measured; the range from low to high includes it.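

Keeping the ethyl on the sulfonamide nitrogen does not by itself preserve the value of compound 3: with 2-bromophenyl in place of 4-methoxyphenyl there is a 3.9-fold higher number from compound 3 to compound 4 (0.59 log units; beyond the scatter), so the aryl group matters at this position. Against the two methyl compounds the change reads only as an at least 1.0-fold lower number from compound 1 to compound 4 (0.02 log units; that floor lies within the scatter) and as an at least 1.0-fold lower number from compound 2 to compound 4 (0.02 log units; that floor lies within the scatter), which shows no gain beyond the scatter. Compound 1 and compound 2 remain limits of the assay, not numbers: the limit of > 100000 nM in this assay, at which 2 of the 4 values shown sit.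

Still open, from the compounds shown here alone, is what a 4-bromophenyl or a 2-methoxyphenyl group would give with the ethyl kept, which would separate the substituent from its place on the ring. A propyl chain in place of the ethyl is equally untested among these compounds.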